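A few compounds are considered here, and "the series" means these few. Any claim that something is new, unique, unknown or untested is made for them only; others in the source may bear on it.

Compound 1 `COc1ccc(-c2cc3cc(C4C(C#N)=C(N)OC5=C4C(=O)CC(C)(C)C5)cc(C(C)C)c3oc2=O)cc1` and compound 2 `CCC(C)c1cc(C2C(C#N)=C(N)OC3=C2C(=O)CC(C)(C)C3)cc2cc(-c3ccc(OC)cc3)c(=O)oc12` were both tested in a functional assay on the whole organism (strain Swiss albino) with Mus musculus as the target, in the forced swim test, with a stated time of 5 min, at a dose of 0.5 mg/kg by the intraperitoneal route; a lower number here means less inhibition, a higher number more inhibition at the dose given (going by the name of the read-out); compound 1 gives 64.9%, and compound 2 gives 26.9%, the lower of the two numbers. Among the compounds with values here, the one measured step, a number 38 percentage points lower from compound 1 to compound 2 (beyond the scatter), concerns a different change. Compound 3 `COc1ccc(-c2cc3cc(C4C(C#N)=C(N)OC5=C4C(=O)CC(C)(C)C5)cc(C(C)(C)C)c3oc2=O)cc1` differs from compound 2 by tert-butyl in place of sec-butyl on an aromatic carbon. Without a step of this kind among the measured compounds, a return toward the number of compound 1 is plausible but uncertain, so the estimate stays wide. Compound 3 is expected to give about 40%, within 15% to 65%. For compound 3 the expected step is a number 13.1 percentage points higher from compound 2 to compound 3 (beyond the scatter).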

Compound 3, a percentage reported as inhibition, in the whole organism at one dose (the size of the read-out at that dose, not a potency): 27.2%
Estimate against measurement, compound 3: 12.8 percentage points above; the measured number falls inside the stated range.
By their numbers in this assay, from the lowest: compounds 2 and 3 (each within the scatter of the next); then compound 1.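

At this aromatic carbon, tert-butyl in place of sec-butyl gives a number 0.3 percentage points higher from compound 2 to compound 3 (within the scatter) in this assay, so this assay does not tell the two groups apart. Methyl in place of hydrogen on the saturated chain carbon bound to the aromatic carbon gives a number 37.7 percentage points lower from compound 1 to compound 3 (beyond the scatter), so the large step seen with sec-butyl also appears with tert-butyl. Nothing available explains this result. The compounds shown leave open how an ethyl group, a cyclopropyl ring or an amine on this aromatic carbon would read in this assay. They also leave open whether these steps hold at other doses.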